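A few compounds are considered here, and "the series" means these few. Any claim that something is new, unique, unknown or untested is made for them only; others in the source may bear on it.

Measured compounds in a functional assay on the whole organism (strain Wistar albino) for inhibition, with Rattus norvegicus as the target, read by paw edema, with a stated time of 3 h, at a dose of 25 mg/kg by the oral route; a higher number here means more inhibition at the dose given (going by the name of the read-out), a lower number less inhibition:
Compound 1, `NS(=O)(=O)c1ccc(-n2nc(Nc3ccccc3)c3c(=O)n(-c4ccccc4)c(Nc4ccccc4)nc32)cc1`, gives 39.7%.
Compound 2, `NS(=O)(=O)c1ccc(-n2nc(Nc3ccc([N+](=O)[O-])cc3)c3c(=O)n(-c4ccccc4)c(Nc4ccccc4)nc32)cc1`, gives 39.1%.
Compound 3, `Cc1ccc(Nc2nn(-c3ccccc3)c3nc(Nc4ccccc4)n(-c4ccccc4)c(=O)c23)cc1`, gives 32.9%.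

Compound 4, `Cc1ccc(Nc2nn(-c3ccc([N+](=O)[O-])cc3)c3nc(Nc4ccccc4)n(-c4ccccc4)c(=O)c23)cc1`, has not yet been measured in this assay. The change from compound 1 to compound 2 is nitro in place of hydrogen on an aromatic carbon and it made a step of a number 0.6 percentage points lower from compound 1 to compound 2 (within the scatter). Compound 3 has the lowest of the three measured numbers, but its gaps to compound 2 and to compound 1 both lie within the scatter, so the three measured compounds cannot be ranked against one another. The difference between the core of compound 1 and the core of compound 3 is not broken down here. Compound 4 differs from compound 3 by nitro in place of hydrogen on an aromatic carbon, the same change that turned compound 1 into compound 2. The step of a number 0.9 percentage points lower from compound 3 to compound 4 (within the scatter) is expected to be as small as the earlier one, because a number 0.6 percentage points lower from compound 1 to compound 2 (within the scatter) stayed within the scatter. On that basis compound 4 is estimated at 32%, with an expected range from 24% to 40%.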

Compound 4, a percentage reported as inhibition, in the whole organism at one dose (the size of the read-out at that dose, not a potency): 30.2%
Compound 4: the middle estimate sits 1.8 percentage points above what was measured; the range from low to high includes it.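

In this assay, the change from phenyl to 4-nitrophenyl gives a number 2.7 percentage points lower from compound 3 to compound 4 (within the scatter), and it does not stand apart from the earlier nitro step: the same change on two cores in this assay, a number 0.6 percentage points lower (within the scatter) from compound 1 to compound 2 and a number 2.7 percentage points lower (within the scatter) from compound 3 to compound 4, 2.1 percentage points apart, within the scatter of two such steps. Nitro in place of hydrogen on an aromatic carbon therefore stays within the scatter on both cores shown, so the outcome carries over between these two pairs. Within the data shown here, this rests on only two pairs, with the nitro on a different ring in compound 2 than in compound 4, and a step within the scatter cannot show that the change does nothing or that the same would hold on other cores.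

The compounds shown leave open whether a different group on the same ring, such as an amine or a carboxylic acid, would give a step beyond the scatter. They also leave open what each part of the difference between the core of compound 1 and the core of compound 3 contributes on its own.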